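Trimming the Thiophene: From Compound 1 to Compound 3

A few compounds are considered here, and "the series" means these few. Any claim that something is new, unique, unknown or untested is made for them only; others in the source may bear on it.

Compound 1 `Cc1cc(-c2nc3sc(C)cn3c2/C=N/NC(=N)N)c(C)s1` was tested in a functional assay on cells (Cancer cell lines, Homo sapiens) for inhibition (a higher number here means a weaker inhibitor of growth, a lower number a stronger inhibitor of growth), where compound 1 gives 4790 nM. Going by the values given here, the only other measured member of the set, compound 2 `Cc1cn2c(/C=N/Nc3ccccn3)c(-c3ccc(Cl)c([N+](=O)[O-])c3)nc2s1`, gives 11700 nM in this assay, so compound 1 holds the lower of the two numbers, and the gap between the two lies beyond the usual scatter. Compound 3 `Cc1cn2c(/C=N/NC(=N)N)c(-c3ccsc3)nc2s1` has not yet been measured. It differs from compound 1 in one place: thiophen-3-yl in place of 2,5-dimethylthiophen-3-yl on an aromatic carbon. Among the compounds with values here, no step between measured compounds bears on this change, so the expectation rests on compound 1 alone. The study expects the step of a 1.4-fold higher number from compound 1 to compound 3 (0.13 log units; within the scatter) to be small, a slight move toward a higher number that may well stay within the scatter. On that basis compound 3 is estimated to give 6500 nM in this assay, within a range from 2200 nM to 19000 nM.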

Compound 3, concentration for 50% growth inhibition: 7590 nM
For compound 3 the middle estimate is 1.2-fold (0.07 log units) below the measured one; the measured number falls inside the stated range.
By their numbers in this assay, from the lowest: compounds 1, 3 and 2 (each within the scatter of the next, the first and the last beyond it).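

In this assay, replacing 2,5-dimethylthiophen-3-yl with thiophen-3-yl on this aromatic carbon gives a 1.6-fold higher number from compound 1 to compound 3 (0.20 log units; within the scatter), the first step read at this position. In this single pair, the two methyl groups on the thiophene can therefore be removed without a difference that this assay separates from the scatter, so the unsubstituted thiophene serves as well as the dimethylated one here. Nothing measured here accounts for how close the two numbers lie.

Going by these compounds alone, it remains open whether a thiophene carrying only one methyl group would behave like these two, and whether a phenyl, a furan-3-yl or a ring bearing an amine at the same place would move the number beyond the scatter. As far as these compounds go, whether the same change reads alike on a core with a different side chain also remains open.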